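Trimming the Cyclohexyl Chain of Compound 2

This account rests on a few compounds, and the source may have more. Where it says the series, first, only, none or still open, it means among the compounds named here.

- Compound 1 `CC(C)CCCOc1cccc(O)c1C(=O)/C=C/c1ccc(O)cc1` gives 11400 nM
- Compound 2 `O=C(/C=C/c1ccc(O)cc1)c1c(O)cccc1OCCC1CCCCC1` gives > 30000 nM

In a functional assay on NCI-H23 cells (Homo sapiens) for antiproliferative activity, read by sulforhodamine B assay (on this read-out higher numbers stand for weaker inhibition of growth and lower numbers for stronger inhibition of growth), compound 2 stands at > 30000 nM, which is a limit and not a number. Compound 3 `O=C(/C=C/c1ccc(O)cc1)c1c(O)cccc1OCC1CCCCC1` has cyclohexyl in place of cyclohexylmethyl on a saturated chain carbon bound to an oxygen on an aromatic ring. Going by the values given here, the one measured step that bears on this is an at least 2.6-fold higher number from compound 1 to compound 2 (0.42 log units; beyond the scatter), also a change at the chain end. Since compound 1 at 11400 nM gives a true number, a modest move to lower numbers seems likely. The expected change is an at least 1.5-fold lower number from compound 2 to compound 3 (0.19 log units; that floor lies within the scatter) in this assay, though a second limit remains possible. For compound 3 the estimate is 19000 nM, with an expected range of 8000 nM to 35000 nM.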

Compound 3, concentration for 50% growth inhibition: > 30000 nM
Compound 3 was reported as a limit; the forecaster's own chance of this, stated with the estimate: 40%; middle value at least 1.5-fold (0.19 log units) from the limit.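

Compound 3 shows that in this assay cyclohexylmethoxy in place of 2-cyclohexylethoxy does not bring back a readable number. Set against the isopentyl chain of compound 1, its cyclohexyl group gives an at least 2.6-fold higher number from compound 1 to compound 3 (0.42 log units; beyond the scatter) and so stays on the weak side, as compound 2 does. The step between compound 2 and compound 3 cannot be read, because each value is a limit and not a number: the limit of > 30000 nM in this assay, at which 2 of the 3 values shown sit.

From the compounds shown here alone, how these two compounds rank stays open. So does what a chain ending in an amine or a cyclopentyl ring would give in this assay.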